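The source may report more compounds than this note shows. Statements on the series, on what has been measured and on what is new or still open speak of the compounds shown alone.

Compound 1 `CCNC(=O)Nc1ccc(/C=C\c2cc(C)cc(C)c2)cc1` and compound 2 `Cc1cc(C)cc(/C=C\c2ccc(N3CCNC3=O)cc2)c1` share one core and differ in one place: 2-oxoimidazolidin-1-yl in place of (ethylcarbamoyl)amino on an aromatic carbon. In a functional assay on HT-1080 cells (Homo sapiens) for inhibition, read by sulforhodamine B assay, with a stated time of 48 h (a lower number here means a stronger inhibitor, a higher number a weaker inhibitor), compound 1 gives 15000 nM, while compound 2 gives 15 nM. The step of a 1000-fold lower number from compound 1 to compound 2 (3.00 log units; beyond the scatter) is the largest movement among the compounds shown, and it is beyond the scatter.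

Compound 3 `CCNC(=O)Nc1ccc(/C=C/c2cc(OC)c(OC)c(OC)c2)cc1` carries the same (ethylcarbamoyl)amino group as compound 1 but on a different core; the difference between the two cores is not broken down here. In this assay compound 3 gives 16000 nM, which lies within the scatter of the value of compound 1, so the two are treated as alike.

Compound 4 `COc1cc(/C=C/c2ccc(N3CCNC3=O)cc2)cc(OC)c1OC` has not been measured. It is related to compound 3 in the same way that compound 2 is related to compound 1: 2-oxoimidazolidin-1-yl in place of (ethylcarbamoyl)amino on an aromatic carbon. The place is described in the same words for both pairs, so the change is the same, not merely the same kind. For the measured compounds named here, because the single measured instance of this change, a 1000-fold lower number from compound 1 to compound 2 (3.00 log units; beyond the scatter), is large and well beyond the scatter, a large step is expected here as well; the only caution is that the change has been measured once and on one core. Compound 4 is expected to show the step of a 640-fold lower number from compound 3 to compound 4 (2.81 log units; beyond the scatter). Compound 4 is estimated at 25 nM, with a range from 6 nM to 150 nM.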

Compound 4, half-maximal inhibitory concentration: 400 nM
For compound 4 the middle estimate is 16-fold (1.20 log units) below the measured one, and the stated range ends below it.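

In this assay the replacement of (ethylcarbamoyl)amino by 2-oxoimidazolidin-1-yl also lowers the number on the second core, a 40-fold lower number from compound 3 to compound 4 (1.60 log units; beyond the scatter), so on both cores shown the change moves the number in the same direction and by a large step. For the compounds shown here, the direction of the change therefore carries from one core to the other, but its size does not, as the two steps set side by side make plain: the same change on two cores in this assay, a 1000-fold lower number (3.00 log units; beyond the scatter) from compound 1 to compound 2 and a 40-fold lower number (1.60 log units; beyond the scatter) from compound 3 to compound 4, 25-fold (1.40 log units) apart, beyond the scatter of two such steps What this does not show is which part of the cores sets the size of the step, as the difference between the two cores is not broken down, and with only two pairs no general rule for other cores can be drawn.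

The compounds shown leave open whether the step would keep its direction on a core bearing other groups, such as a hydroxyl group or a chlorine atom in place of the methyl or methoxy groups. They also leave open how the number would move with a longer chain in place of the ethyl group of the urea, or with an amine or a carboxylic acid in place of the 2-oxoimidazolidin-1-yl group.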